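Aryl amine change on a shared core, cytotoxicity in MCF7 cells

The source may hold more compounds than are shown below. What is called first, only, known or untested is meant among the compounds shown, and "the series" means these compounds.

Measured so far:
Compound 1, `C=C1[C@@H](OC(C)=O)C[C@@H]2[C@](C)(COC=O)[C@H](OC(C)=O)CC[C@@]2(C)[C@@H]1C[C@@H](Nc1ccccc1C(=O)O)C1=CCOC1=O`: 30800 nM
Compound 2, `C=C1[C@@H](OC(C)=O)C[C@@H]2[C@](C)(COC=O)[C@H](OC(C)=O)CC[C@@]2(C)[C@@H]1C[C@@H](Nc1ccc(OC)c(OC)c1)C1=CCOC1=O`: > 50000 nM

Both compounds share one core and differ only in the group on the amine nitrogen. In a functional assay on MCF7 cells (Homo sapiens) for cytotoxicity, read by sulforhodamine B assay (on this read-out lower numbers stand for stronger inhibition and higher numbers for weaker inhibition), compound 1 gives 30800 nM. Compound 2 reaches only the limit of the assay, > 50000 nM, so no number is known for it (the limit of > 50000 nM in this assay, at which 1 of the 2 values shown sits). The step of an at least 1.6-fold higher number from compound 1 to compound 2 (0.21 log units; that floor lies within the scatter) is therefore a floor, and it lies within the scatter of this assay.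

Compound 3, `C=C1[C@@H](OC(C)=O)C[C@@H]2[C@](C)(COC=O)[C@H](OC(C)=O)CC[C@@]2(C)[C@@H]1C[C@@H](Nc1ccc(O)cc1)C1=CCOC1=O`, has not yet been measured. It differs from compound 2 in one place (4-hydroxyphenyl in place of 3,4-dimethoxyphenyl on an amine nitrogen). For the measured compounds named here, no measured step follows this change, so the only guide is that compound 2 sits at the limit and compound 1, with a different group on the same nitrogen, is weak as well. Compound 3 is therefore expected to stay weak, with an estimated step of an at least 1.1-fold lower number from compound 2 to compound 3 (0.04 log units; that floor lies within the scatter) that lies within the scatter. For compound 3 the estimated value in this assay is 45000 nM, with a range from 15000 nM to 130000 nM.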

Compound 3, half-maximal inhibitory concentration: 18100 nM
Estimate against measurement, compound 3: 2.5-fold (0.40 log units) above, within the range that was stated.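

In this assay, for the compounds shown here, the group on the amine nitrogen can shift the result: putting 4-hydroxyphenyl in place of 3,4-dimethoxyphenyl gives an at least 2.7-fold lower number from compound 2 to compound 3 (0.44 log units; beyond the scatter), the first step in this short series to clear the scatter. Putting 4-hydroxyphenyl in place of 2-carboxyphenyl gives a 1.7-fold lower number from compound 1 to compound 3 (0.23 log units; within the scatter), so these two groups cannot be ranked against each other on this read-out. Compound 2 gives a limit and not a number, so the size of its step is known only as a floor: the limit of > 50000 nM in this assay, at which 1 of the 3 values shown sits.

The change from compound 2 removes two methoxy groups and adds a hydroxy group in a single move, so the compounds shown cannot separate the two effects; a plain phenyl group on the same nitrogen would help to pull them apart. On these data alone, whether an aromatic ring is needed on this nitrogen also stays open, and a simple alkyl chain or a saturated cyclohexyl group there would address that question.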